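Aryl-alkyne propanoic acids at free fatty acid receptor 1

The source may report more compounds than this note shows. Statements on the series, on what has been measured and on what is new or still open speak of the compounds shown alone.

Of the compounds shown here, three have been measured in an in vitro functional assay on 1321-N1 cells for agonist activity at Free fatty acid receptor 1 (Homo sapiens), read by fluorescence, spectrophotometry and calcium flux; a higher number here means that more compound is needed for the effect, a lower number that less compound is needed. Compound 1 `O=C(O)CCc1ccc(C#Cc2ccnc(Cl)c2Cc2ccccc2)cc1` gives 794 nM. Compound 2 `O=C(O)CCc1ccc(C#Cc2ncccc2[N+](=O)[O-])cc1` gives 11000 nM. Compound 3 `Cc1ccsc1C#Cc1ccc(CCC(=O)O)cc1` gives 75.9 nM, the lowest of the three numbers; its nearest neighbour is compound 1, and the gap to compound 2 is wider still, both gaps beyond the usual scatter. Within the data shown here, compound 3 is thus the most potent compound measured so far.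

Compound 4 `O=C(O)CCc1ccc(C#Cc2cncs2)cc1` has not yet been measured in this assay. It differs from compound 3 in one place: 1,3-thiazol-5-yl in place of 3-methylthiophen-2-yl on a triple-bonded carbon.

Among the measured compounds shown here, no step between measured compounds carries this change, so its size is not known from the series. A step in the direction of a higher number is expected from compound 3 to compound 4, moderate in size, because compound 3 at 75.9 nM already stands well apart from the other two and only the aryl group on the alkyne is altered. Compound 4 is expected to give 300 nM, within a range from 80 nM to 1200 nM, which means a step of a 4.0-fold higher number from compound 3 to compound 4 (0.60 log units; beyond the scatter).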

Compound 4, half-maximal effective concentration: 3890 nM
Compound 4: the middle estimate sits 13-fold (1.11 log units) below what was measured; the measured number lies above the stated range.
By their numbers in this assay, from the lowest: compound 3; then compound 1; then compound 4; then compound 2.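

Among these compounds, the aryl group on the alkyne is a sensitive place: in this assay, replacing only this group gives a 51-fold higher number from compound 3 to compound 4 (1.71 log units; beyond the scatter), while the rest of the structure stays the same. This single step combines two edits, the loss of the methyl group and the entry of a ring nitrogen, and the result cannot divide the effect between them. Nothing measured here bears on why the step is so large.

Going by these compounds, an unsubstituted thiophen-2-yl group, or a methyl-bearing thiazole, would separate the two edits, and both remain open. Also open, on these data alone, is whether an ethyl group or a methoxy group in place of the methyl group on the thiophene would retain the low number of compound 3 .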